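This account rests on a few compounds, and the source may have more. Where it says the series, first, only, none or still open, it means among the compounds named here.

Three compounds share one core and differ only in the aryl group carried on it. Compound 1 `CCCCCc1c(C(C)C)nc(C(C)C)c(CO)c1-c1ccc(OC)cc1` gives 37% in an assay on CHO cells for inhibition of Glucagon receptor (Homo sapiens), tested at 20 uM (a lower number here means less inhibition, a higher number more inhibition at the concentration tested (going by the name of the read-out)), and compound 2 `CCCCCc1c(C(C)C)nc(C(C)C)c(CO)c1-c1ccc(O)cc1` gives 24%. Compound 3 `CCCCCc1c(C(C)C)nc(C(C)C)c(CO)c1-c1cccc(C)c1` gives 46%, the highest of the three numbers, though the step of a number 9 percentage points higher from compound 1 to compound 3 (within the scatter) lies within the scatter, while the step of a number 22 percentage points higher from compound 2 to compound 3 (beyond the scatter) lies beyond it. Compound 4 `CCCCCc1c(C(C)C)nc(C(C)C)c(CO)c1-c1ccc(C(C)C)cc1` has not been measured. It differs from compound 3 at the aryl group: 4-isopropylphenyl in place of 3-methylphenyl on an aromatic carbon. Both measured steps that change the aryl group bear on this: the change from compound 1 to compound 3 was a number 9 percentage points higher from compound 1 to compound 3 (within the scatter), and from compound 2 to compound 3 it was a number 22 percentage points higher from compound 2 to compound 3 (beyond the scatter). Neither involves a 4-isopropylphenyl, so the direction of the new step is uncertain, and the earlier aryl changes were at most modest. The step from compound 3 to compound 4 is therefore expected to be small, a number 2 percentage points higher from compound 3 to compound 4 (within the scatter), within or near the scatter. Compound 4 is accordingly estimated at 48%, with a likely range from 30% to 65%.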

Compound 4, a percentage reported as inhibition, at one concentration (the size of the read-out at that concentration, not a potency): 34%
Beside the measured number, compound 4's estimate is 14 percentage points above it; the range from low to high includes it.
By their numbers in this assay, from the lowest: compounds 2, 4, 1 and 3 (each within the scatter of the next, the first and the last beyond it).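

In this assay, 4-isopropylphenyl in place of 3-methylphenyl gives a number 12 percentage points lower from compound 3 to compound 4 (beyond the scatter) even though both groups are carbon-only aromatic rings with no hydrogen-bond donors or acceptors, so this position can register a change that those counts do not capture. Isopropyl in place of hydroxy gives a number 10 percentage points higher from compound 2 to compound 4 (within the scatter) and isopropyl in place of methoxy gives a number 3 percentage points lower from compound 1 to compound 4 (within the scatter) and so compound 4 does not separate from either of the other compounds with a group at the 4-position of the aryl ring. Nothing available gives a reason for these steps.

The step from compound 3 to compound 4 alters both the place and the size of the aryl substituent at once, and the compounds shown leave open which of the two matters. A 3-isopropylphenyl or a 4-methylphenyl group would separate them.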